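This account rests on a few compounds, and the source may have more. Where it says the series, first, only, none or still open, it means among the compounds named here.

Of the compounds shown here, three built on a shared core have been measured in a functional assay on SK-BR-3 cells (Homo sapiens) for antiproliferative activity, read by MTT assay, with a stated time of 72 h; a higher number here means a weaker inhibitor, a lower number a stronger inhibitor. Compound 1 `CCN1CCN(c2cc(C)c3cc(NC(=O)c4ccccc4F)ccc3n2)CC1` gives 38100 nM, and compound 3 `CCc1ccccc1C(=O)Nc1ccc2nc(N3CCN(CC)CC3)cc(C)c2c1` gives 23900 nM; between them lies the step of a 1.6-fold lower number from compound 1 to compound 3 (0.20 log units; within the scatter). Compound 2 `Cc1cc(NCCN(C)C)nc2ccc(NC(=O)c3ccc(Cl)c(Cl)c3)cc12` gives the lowest of the three numbers, 6670 nM, beyond the scatter from both compound 3 and compound 1. Compound 4 `Cc1cc(N(C)C)nc2ccc(NC(=O)c3ccc(Cl)c(Cl)c3)cc12` differs from compound 2 in one place: dimethylamino in place of (2-(dimethylamino)ethyl)amino on an aromatic carbon. Among the measured compounds shown here, no measured step touches this place; the single known step lies elsewhere and stays within the scatter, so it offers no guide. Compounds 1 and 3 carry another group at this place and give higher numbers than compound 2, though their amides also differ. A moderate rise is therefore expected, as a 2.2-fold higher number from compound 2 to compound 4 (0.35 log units; beyond the scatter). For compound 4 the estimate in this assay is 15000 nM, from 4000 nM to 60000 nM.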

Compound 4, half-maximal inhibitory concentration: > 50000 nM
Compound 4: a limit, no number; the forecaster's own chance of this, stated with the estimate: 5%; middle value at least 3.3-fold (0.52 log units) from the limit.
By their numbers in this assay, from the lowest: compound 2; then compounds 3 and 1 (each within the scatter of the next). At a limit, above all of these: compound 4.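

In this assay, among the compounds shown here, this position gives the first step beyond the scatter, an at least 7.4-fold higher number from compound 2 to compound 4 (0.87 log units; beyond the scatter), with the amide of compound 2 unchanged. Exchanging the (2-(dimethylamino)ethyl)amino group on this aromatic carbon next to the ring nitrogen for dimethylamino therefore moves the reading clearly upward. For compound 4 the reading is a limit, not a number: the limit of > 50000 nM in this assay, at which 1 of the 4 values shown sits.

On these data alone, whether a longer chain or a chain ending in a carboxylic acid would keep or lower the number of compound 2 remains open. Also open, as far as these compounds go, is how the group carried by compounds 1 and 3 would read alongside the amide of compound 2.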